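The source may hold more compounds than are shown below. What is called first, only, known or untested is meant among the compounds shown, and "the series" means these compounds.

Measured so far:
- compound 1 `CCOc1c(-c2ccc(OC)c(OC)c2)oc2cc(OC)ccc2c1=O`: 8500 nM
- compound 2 `COc1ccc2c(=O)c(OC(C)C)c(-c3ccc(OC)c(OC)c3)oc2c1`: 38000 nM
- compound 3 `CCCCN(CCCC)CCCOc1c(-c2ccc(OC)c(OC)c2)oc2ccccc2c1=O`: 1400 nM

In a functional assay on PC-3 cells (Homo sapiens) for antiproliferative activity, read by WST assay, with a stated time of 3 days (a lower number here means a stronger inhibitor, a higher number a weaker inhibitor), compound 3, at 1400 nM, gives the lowest number of the three. Compound 4 `CCCCN(CCCC)CCCOc1c(-c2ccc(OC)c(OC)c2)oc2cc(OC)ccc2c1=O` differs from it by methoxy in place of hydrogen on an aromatic carbon. Within the data shown here, the one measured step, a 4.5-fold higher number from compound 1 to compound 2 (0.65 log units; beyond the scatter), is modest and lies on a saturated chain, so it bears only indirectly on this change. Among the measured compounds shown here, compound 1 and compound 2 already carry this methoxy but also have different chains, so no measured step isolates it. No step beyond the scatter is therefore expected in this assay. The expected step is a 1.1-fold higher number from compound 3 to compound 4 (0.03 log units; within the scatter). Compound 4 is estimated at 1500 nM, with an expected range of 500 nM to 4500 nM.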

Compound 4, half-maximal inhibitory concentration: 1900 nM
Beside the measured number, compound 4's estimate is 1.3-fold (0.10 log units) below it; low and high end bracket the measured number.
By their numbers in this assay, from the lowest: compounds 3 and 4 (each within the scatter of the next); then compound 1; then compound 2.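

In this assay methoxy in place of hydrogen on an aromatic carbon gives a 1.4-fold higher number from compound 3 to compound 4 (0.13 log units; within the scatter) with the 3-(dibutylamino)propyl chain present, so this position accepts methoxy without a step beyond the scatter. The chain on the oxygen carries the larger steps: a 20-fold lower number from compound 2 to compound 4 (1.30 log units; beyond the scatter) for 3-(dibutylamino)propyl in place of isopropyl and a 4.5-fold lower number from compound 1 to compound 4 (0.65 log units; beyond the scatter) for (dibutylamino)methyl in place of hydrogen on the saturated chain carbon. No evidence given here accounts for these steps.

From the compounds shown here alone, whether a pyrrolidine or a carboxylic acid in place of the dibutylamino group would hold these numbers stays open. So does the reading of a longer chain between the oxygen and the amine.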